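A few compounds are considered here, and "the series" means these few. Any claim that something is new, unique, unknown or untested is made for them only; others in the source may bear on it.

In a functional assay on IGROV-1 cells (Homo sapiens) for inhibition, read by sulforhodamine B assay, with a stated time of 48 h (a lower number here means that less compound is tolerated, a higher number that more compound is tolerated), compound 1, with the structure `Nc1cc(N)c2nc(-c3ccccc3)c(Oc3ccc(Cl)c(Cl)c3)nc2c1`, gives 91200 nM. Compound 2, `COc1ccc(CNc2nc3cc(N)cc(N)c3nc2-c2ccccc2)cc1OC`, returns only a limit of this assay, < 100000 nM. Compound 3, `Nc1cc(N)c2nc(-c3ccccc3)c(NCc3ccc(F)cc3)nc2c1`, likewise returns only a limit in this assay, < 100000 nM, so where compound 3 stands is a bound rather than a point. The step that the limit leaves unreadable from compound 1 to compound 3 and the step that the two limits leave unreadable from compound 2 to compound 3 are both unreadable for that reason, and the limit of < 100000 nM in this assay, at which 2 of the 3 values shown sit, marks where two of the three values sit. Compound 4, `Nc1cc(N)c2nc(-c3ccccc3)c(Sc3ccc(Cl)c(Cl)c3)nc2c1`, has not been measured. The change is (3,4-dichlorophenyl)sulfanyl in place of (4-fluorobenzyl)amino on an aromatic carbon. Among the measured compounds shown here, no measured step bears directly on this exchange. Compound 1 does carry a 3,4-dichlorophenoxy group on that aromatic carbon, and compound 4 carries the closely related (3,4-dichlorophenyl)sulfanyl group there, so compound 4 is expected to land near the value of compound 1 in this assay. The step that the limit leaves unreadable from compound 3 to compound 4 is therefore expected to be small, with its direction uncertain. Compound 4 is estimated at 70000 nM, within a range of 25000 nM to 150000 nM.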

Compound 4, concentration lethal to 50% of the cells: < 100000 nM
Compound 4 ended at the assay's limit; the forecaster's own chance of this, stated with the estimate: 40%; the middle value does not contradict the limit.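

Compound 4 returns only a limit, < 100000 nM, and neither its step from compound 3 nor its step from compound 1 can be read. Still open, from the compounds shown here alone, is how (3,4-dichlorophenyl)sulfanyl compares with 3,4-dichlorophenoxy or (4-fluorobenzyl)amino on that aromatic carbon in this assay, with most values sitting at one bound: the limit of < 100000 nM in this assay, at which 3 of the 4 values shown sit.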